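Phenyl ring substitution on the shared core, methoxy step

This account rests on a few compounds, and the source may have more. Where it says the series, first, only, none or still open, it means among the compounds named here.

Compound 1 `Cn1c(-c2ccccc2)nc2c(NC3CCCC3)ncnc21` is the reference point. In an assay on CHO cells for displacement of a labelled ligand from adenosine receptor A3 (Homo sapiens), read by scintillation counting, with a stated time of 3 h (a lower number here means a stronger inhibitor, a higher number a weaker inhibitor), compound 1 gives 846 nM, the highest of the three numbers at hand. Compound 3 `CCn1c(-c2ccccc2)nc2c(NC3CCCCC3)ncnc21` gives 707 nM, the nearest to compound 1 and within the scatter of it. Compound 2 `Cn1c(-c2cccc(Cl)c2)nc2c(NC3CCCC3)ncnc21` gives 514 nM, the furthest from compound 1 and still within the scatter. Within the data shown here, the one step that rests on a single change, a 1.6-fold lower number from compound 1 to compound 2 (0.22 log units; within the scatter), shows that putting a substituent onto the phenyl ring of the shared core has so far moved the number by less than the scatter.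

Compound 4 `COc1ccc(-c2nc3c(NC4CCCC4)ncnc3n2C)cc1` is not yet measured. It differs from compound 1 by methoxy in place of hydrogen on an aromatic carbon. The step from compound 1 to compound 2 is the only measured one that bears on this change, since it also puts a substituent on the same phenyl ring, and it stayed within the scatter. Among the measured compounds shown here, with that as the sole guide, the methoxy group is expected to leave the number near that of compound 1, with no step beyond the scatter in either direction. For compound 4 the estimate is 700 nM, with a range from 300 nM to 1700 nM. This estimate means a step of a 1.2-fold lower number from compound 1 to compound 4 (0.08 log units; within the scatter), expected to fall within the scatter.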

Compound 4, inhibition constant: 1850 nM
Compound 4: the middle estimate sits 2.6-fold (0.42 log units) below what was measured, outside the stated range (above it).
By their numbers in this assay, from the lowest: compounds 2, 3 and 1 (each within the scatter of the next); then compound 4.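

In this assay the change from phenyl to 4-methoxyphenyl gives a 2.2-fold higher number from compound 1 to compound 4 (0.34 log units; beyond the scatter) and is the only one of the two single changes on this ring to pass the scatter, modestly and toward a weaker inhibitor. Substitution on this ring therefore does not always leave the number in place, as the chloro step alone had suggested, and the methoxy group on this aromatic carbon, para to a large group, is the case that moves it. The comparison of the two substituted compounds, with a 3.6-fold higher number from compound 2 to compound 4 (0.56 log units; beyond the scatter) and 4-methoxyphenyl in place of 3-chlorophenyl, is also beyond the scatter, but it changes the group and its place together, and nothing at hand accounts for the higher number with the methoxy group.

The compounds shown leave open whether the higher number belongs to methoxy itself or to any group on this aromatic carbon, and whether the same group elsewhere on the ring would behave alike. A hydroxy group, an amine or a longer ethoxy chain on the same carbon would bear on that question.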